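Adding Chlorine to the Phenyl Group of Compound 1

The source may report more compounds than this note shows. Statements on the series, on what has been measured and on what is new or still open speak of the compounds shown alone.

Of the compounds shown here, two built on the same core have so far been measured in a functional assay on UACC-62 cells (Homo sapiens) for inhibition; a lower number here means a stronger inhibitor of growth, a higher number a weaker inhibitor of growth. Compound 1 `COc1cc(/C=C/C(=O)c2cccc(-n3cc(-c4ccccc4)[nH]c3=O)c2)ccc1O` gives 2010 nM in this assay. Compound 2 `COc1cc(/C=C/C(=O)c2cccc(-n3cc(-c4ccccc4)[nH]c3=O)c2)cc(OC)c1OC` gives 1520 nM in this assay. Of the two numbers, that of compound 1 is the higher one, but the gap to compound 2 lies within the scatter of repeated measurements, so the two compounds cannot be told apart on these numbers alone.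

Compound 3 `COc1cc(/C=C/C(=O)c2cccc(-n3cc(-c4ccc(Cl)cc4)[nH]c3=O)c2)ccc1O` has not yet been measured. It differs from compound 1 in a single place: chloro in place of hydrogen on an aromatic carbon. Among the measured compounds shown here, no pair of measured compounds shows what this exchange does in this assay, so there is nothing in the numbers that points to a direction. The expectation therefore leans on the closeness of the two measured values and on the small size of the change. The step of a 1.3-fold lower number from compound 1 to compound 3 (0.10 log units; within the scatter) is expected to be small, not clearly beyond the scatter in either direction. Compound 3 is accordingly estimated at 1600 nM, with a range from 500 nM to 5000 nM.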

Compound 3, concentration for 50% growth inhibition: 2740 nM
Estimate against measurement, compound 3: 1.7-fold (0.23 log units) below, and the stated range covers the measured number.
By their numbers in this assay, from the lowest: compounds 2, 1 and 3 (each within the scatter of the next).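

Among the compounds shown here, this is the first single change that can be read directly: replacing phenyl with 4-chlorophenyl, which puts chloro in place of hydrogen on an aromatic carbon para to a large group, gives a 1.4-fold higher number from compound 1 to compound 3 (0.13 log units; within the scatter) in this assay. A step of this size cannot be separated from the ordinary variation between repeated measurements, so the two compounds cannot be told apart here, and at this position the hydrogen can be exchanged for chloro with no clear effect on the read-out. No accompanying measurement bears on this result, so the numbers offer no explanation for it.

One chlorine atom at one position does not show how this place would respond to other groups, such as an amine, a carboxylic acid or a longer chain. As far as these compounds go, it also remains open whether the same exchange of hydrogen for chloro would give a similarly small step when made on compound 2, which differs from compound 1 in its other aromatic ring.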